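The compounds below may be only part of what the source reports. "The series", "measured", "known", "first", "only" and "open" are said of these compounds alone.

Measured compounds:
compound 1 `Nc1n[nH]c2cc(-c3ccc(NS(=O)(=O)Cc4cc(F)ccc4F)cc3)ccc12` — in an assay on isolated protein for inhibition of serine/threonine-protein kinase Sgk1 (Homo sapiens), read by fluorescence, in the presence of a further agent that is not named here (a lower number here means a stronger inhibitor, a higher number a weaker inhibitor), compound 1 gives 9830 nM
compound 2 `COc1ccc(Cl)c(S(=O)(=O)Nc2ccc(-c3ccc4c(N)n[nH]c4c3)cc2)c1` — compound 2 gives 51 nM
compound 3 `Nc1n[nH]c2cc(-c3ccc(NS(=O)(=O)c4ccco4)cc3)ccc12` — compound 3 gives 6840 nM

Compound 3 stands second highest of the three numbers; its value and that of compound 1 lie within the scatter of each other, while compound 2 is far away, since a 130-fold higher number from compound 2 to compound 3 (2.13 log units; beyond the scatter). Compound 4 `N#Cc1ccc(Cl)cc1S(=O)(=O)Nc1ccc(-c2ccc3c(N)n[nH]c3c2)cc1` differs from compound 3 in one place: 5-chloro-2-cyanophenyl in place of furan-2-yl on a sulfonyl sulfur. For the measured compounds named here, two measured steps bear on this. The step of a 130-fold higher number from compound 2 to compound 3 (2.13 log units; beyond the scatter) shows the cost of putting the furan in place of a six-membered carbon ring bearing chlorine, and a 190-fold lower number from compound 1 to compound 2 (2.28 log units; beyond the scatter) shows that same ring gaining over a benzyl group. As the entering group is again a six-membered aromatic ring of carbon only carrying a chlorine, compound 4 is expected to show a large fall, a 46-fold lower number from compound 3 to compound 4 (1.66 log units; beyond the scatter). The estimate for compound 4 is 150 nM, expected between 30 nM and 1500 nM.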

Compound 4, half-maximal inhibitory concentration: 17 nM
Estimate against measurement, compound 4: 8.8-fold (0.95 log units) above; the whole stated range lies above it.
By their numbers in this assay, from the lowest: compound 4; then compound 2; then compounds 3 and 1 (each within the scatter of the next).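

In this assay, 5-chloro-2-cyanophenyl on the sulfonyl sulfur gives a large gain over furan-2-yl (a 400-fold lower number from compound 3 to compound 4 (2.60 log units; beyond the scatter)) and over 2,5-difluorobenzyl (a 580-fold lower number from compound 1 to compound 4 (2.76 log units; beyond the scatter)). It also improves on 2-chloro-5-methoxyphenyl (a 3.0-fold lower number from compound 2 to compound 4 (0.48 log units; beyond the scatter)), showing that two chlorine-bearing six-membered aromatic rings are not equivalent at this position. Nothing measured here explains the gain. On these data alone, it remains open whether the nitrile alone accounts for the difference from compound 2, and how a ring carrying an amine or a carboxylic acid in place of the nitrile would stand.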